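A few compounds are considered here, and "the series" means these few. Any claim that something is new, unique, unknown or untested is made for them only; others in the source may bear on it.

Of the compounds shown here, two have so far been measured in a functional assay on BCG823 cells (Homo sapiens) for inhibition, read by MTT assay, with a stated time of 72 h; on this read-out lower numbers stand for stronger inhibition and higher numbers for weaker inhibition. Compound 1 `Cc1nc(N(C)C(=O)NC(=O)c2c(F)cccc2F)sc1C(=O)N/N=C/c1ccc(C(F)(F)F)cc1` gives 65.5 ug/mL in this assay. Compound 2 `CN(C(=O)NC(=O)c1ccccc1F)c1nc(C(F)(F)F)c(C(=O)N/N=C/c2ccc(C(F)(F)F)cc2)s1` gives 3.87 ug/mL in this assay, the lowest of the two numbers, and its gap to compound 1 lies beyond the scatter. Compound 3 `CN(C(=O)NC(=O)c1ccc(Cl)cc1Cl)c1nc(C(F)(F)F)c(C(=O)N/N=C/c2ccc(C(F)(F)F)cc2)s1` awaits measurement. It differs from compound 2 by a single exchange: 2,4-dichlorophenyl in place of 2-fluorophenyl on a carbonyl carbon. Going by the values given here, no measured pair differs by this exchange alone, so the size of the step has no precedent among the compounds at hand, and the starting point is the lowest number seen. The step is expected to be small, within the scatter or only slightly beyond it, and no clear direction can be read from the data, so a 1.2-fold higher number from compound 2 to compound 3 (0.07 log units; within the scatter) is the estimated outcome. Compound 3 is therefore expected to give about 4.5 ug/mL in this assay, with a range from 1.5 ug/mL to 15 ug/mL.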

Compound 3, half-maximal inhibitory concentration: 3.08 ug/mL
Beside the measured number, compound 3's estimate is 1.5-fold (0.16 log units) above it; the measured number falls inside the stated range.
By their numbers in this assay, from the lowest: compounds 3 and 2 (each within the scatter of the next); then compound 1.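

In this assay, putting 2,4-dichlorophenyl in place of 2-fluorophenyl on the carbonyl carbon gives a 1.3-fold lower number from compound 2 to compound 3 (0.10 log units; within the scatter). This is the first single exchange that can be read among the compounds shown, and it indicates that, on this core, this position accepts both aryl groups with no difference that the assay can resolve. Nothing at hand explains this outcome.

As far as these compounds go, both groups are halogen-bearing phenyl rings, so it remains open whether the position would hold its number with an unsubstituted phenyl, a pyridine, a saturated ring such as cyclohexyl, or a phenyl carrying an amine or a carboxylic acid. Compound 1 differs from compound 2 in more than one place, so its higher number cannot be assigned to any single change.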